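A Methyl Added to a Compound Known Only by a Limit

The source may report more compounds than this note shows. Statements on the series, on what has been measured and on what is new or still open speak of the compounds shown alone.

In a functional assay on HepG2 cells (Homo sapiens) for inhibition, read by sulforhodamine B assay, with a stated time of 74 h (a lower number here means a stronger inhibitor, a higher number a weaker inhibitor), compound 1 (`Cc1ccc(S(=O)(=O)N2C(=O)COC23C=CC(=O)C=C3)cc1`) gives > 10000 nM as a limit of the assay and not a number. Compound 2 (`CS(=O)(=O)N1C(=O)COC12C=CC(=O)C=C2`) likewise gives > 10000 nM as a limit. Among the compounds with values here, only one measured step is available, and a step that the two limits leave unreadable from compound 1 to compound 2 is a change on the sulfonyl sulfur with no size to carry forward. Compound 3 (`Cc1ccc(S(=O)(=O)N2C(=O)C(C)OC23C=CC(=O)C=C3)cc1`) carries a single change from compound 1: methyl in place of hydrogen on a saturated ring carbon and the rest of the structure stays the same. Within the data shown here, no measured step shows what a methyl does at this place, so the data give neither a size nor a direction. The expectation in this assay is therefore no shift beyond the scatter, and another result given only as a limit is the likeliest outcome. The expected move is a step that the limit leaves unreadable from compound 1 to compound 3 and it remains only an estimate. For compound 3 the estimated value is 12000 nM with an expected range of 3000 nM to 40000 nM around it.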

Compound 3, half-maximal inhibitory concentration: 540 nM
Compound 3: the middle estimate sits 22-fold (1.35 log units) above what was measured; the measured number lies below the stated range.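

In this assay, a methyl on the saturated ring carbon next to the ring oxygen gives an at least 18-fold lower number from compound 1 to compound 3 (1.26 log units; beyond the scatter), so a single added methyl at this position can matter a great deal. On these data alone, compound 1 is known only by a limit, so this step is a minimum and its full size stays unknown. Compound 3 is the only compound shown with a readable number, which gives further changes a measured point of comparison, while the others stop at a limit: the limit of > 10000 nM in this assay, at which 2 of the 3 values shown sit.

The compounds shown do not tell whether an ethyl group, a longer chain or an amine on the same carbon would give a similar result. They also leave open whether the same methyl would have a comparable effect with methyl in place of 4-methylphenyl on the sulfonyl sulfur, and they offer no explanation for the step.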